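This account rests on a few compounds, and the source may have more. Where it says the series, first, only, none or still open, it means among the compounds named here.

Measured compounds:
Compound 1, `CCCc1nc(C)n2c(O)nncc12` — in a functional assay for inhibition, with Homo sapiens as the target (a lower number here means a stronger inhibitor, a higher number a weaker inhibitor), compound 1 gives > 48000 nM, which is a limit of the assay and not a number.
Compound 2, `Cc1nc(C)n2c(O)nncc12` — in this assay compound 2 gives > 48000 nM, again a limit of the assay rather than a number.

From the compounds shown here alone, compound 2 thus stands at the edge of what this assay can report; how much weaker it truly is remains unknown. For the measured compounds named here, the one step among the measured compounds, a step that the two limits leave unreadable from compound 1 to compound 2, cannot be read in size, since both of its end points sit at the same limit, as the limit of > 48000 nM in this assay, at which 2 of the 2 values shown sit, shows.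

Compound 3 is `Cc1nc(C(C)(C)C)n2c(O)nncc12`, not yet measured. It differs from compound 2 in one place: tert-butyl in place of methyl on an aromatic carbon.

Going by the values given here, no measured step touches this part of the shared core, so the only guide is that both compounds tested so far sit at the limit in this assay. The exchange from compound 1 to compound 2 did not bring either into the readable range. The step that the limit leaves unreadable from compound 2 to compound 3 is therefore expected to show no readable change, with compound 3 most likely also reported only as a limit. Compound 3 is estimated at 60000 nM, within 20000 nM to 200000 nM.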

Compound 3, half-maximal inhibitory concentration: 31000 nM
The estimate for compound 3 lay 1.9-fold (0.29 log units) above the measured number, and the stated range covers the measured number.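

Putting tert-butyl in place of methyl on this aromatic carbon, between two ring nitrogen atoms, yields the only actual number shown so far in this assay: compound 3 gives 31000 nM. Compound 2 gives > 48000 nM, which is a limit of the assay and not a number. What can be read is an at least 1.5-fold lower number from compound 2 to compound 3 (0.18 log units; that floor lies within the scatter), and this is only a floor, with the true gap possibly larger because compound 2 has no exact number: the limit of > 48000 nM in this assay, at which 2 of the 3 values shown sit.

Methyl and tert-butyl are the only groups shown at this position, leaving open whether the result follows the number of carbon atoms or the branched shape of tert-butyl, a question that an isopropyl group or a straight butyl chain could help to answer. From the compounds shown here alone, it also remains open how a group of a different kind, such as an amine or a carboxylic acid, would read here, and the step from compound 1 to compound 2 cannot be read, leaving the effect of the chain at the other ring position unknown.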